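Methyl on a piperidine ring: one step, repeated

The compounds below may be only part of what the source reports. "The series", "measured", "known", "first", "only" and "open" are said of these compounds alone.

Compound 1, `O=C1CN(C2CCCC2)c2nc(Nc3ccc(N4CCCCC4)cc3)ncc2N1`, in a functional assay on HT-29 cells (Homo sapiens) for inhibition, read by MTT assay, with a stated time of 48 h (on this read-out lower numbers stand for stronger inhibition and higher numbers for weaker inhibition), gives 5540 nM. Compound 2, `CC1CCN(c2ccc(Nc3ncc4c(n3)N(C3CCCC3)CC(=O)N4)cc2)CC1`, in this assay gives 5040 nM. Compound 3, `CN1C(=O)CN(C2CCCC2)c2nc(Nc3ccc(N4CCCCC4)cn3)ncc21`, in this assay gives 12500 nM.

Compound 2 differs from compound 1 by methyl in place of hydrogen on a saturated ring carbon, and that change gave a 1.1-fold lower number from compound 1 to compound 2 (0.04 log units; within the scatter). Compound 4, `CC1CCN(c2ccc(Nc3ncc4c(n3)N(C3CCCC3)CC(=O)N4C)nc2)CC1`, is not yet measured; it differs from compound 3 by methyl in place of hydrogen on a saturated ring carbon. The difference between the core of compound 3 and the core of compound 1 is not broken down here. The place of the change reads the same for both pairs, so it is the same change made on a different core. Compound 3 stands at the highest number of the three measured in this assay.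

Because the earlier step gave a 1.1-fold lower number from compound 1 to compound 2 (0.04 log units; within the scatter), compound 4 is expected to show a step of about a 1.1-fold lower number from compound 3 to compound 4 (0.04 log units; within the scatter). Compound 4 is accordingly estimated at 11500 nM, with a likely range from 4000 nM to 30000 nM.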

Compound 4, half-maximal inhibitory concentration: 11300 nM
Compound 4: the middle estimate sits 1.0-fold (0.01 log units) above what was measured; measured number inside the range.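

In this assay, the change from piperidin-1-yl to 4-methylpiperidin-1-yl gave a 1.1-fold lower number from compound 3 to compound 4 (0.04 log units; within the scatter). Set beside the earlier step, the two steps agree: the same change on two cores in this assay, a 1.1-fold lower number (0.04 log units; within the scatter) from compound 1 to compound 2 and a 1.1-fold lower number (0.04 log units; within the scatter) from compound 3 to compound 4, 1.0-fold (0.00 log units) apart, within the scatter of two such steps. This shows that on these two cores the methyl produced no step beyond the scatter, but it does not show that the change would behave the same way on any other core in the series or in any other assay.

The compounds shown carry only hydrogen or methyl at this place on the ring, so the outcome with an ethyl, a hydroxyl or an amine there remains open. Also open, from the compounds shown here alone, is what each part of the difference between the two cores contributes on its own.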